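Hydroxamate chains in the series: compound 1 to compound 3

This account rests on a few compounds, and the source may have more. Where it says the series, first, only, none or still open, it means among the compounds named here.

Measured in a functional assay on HeLa cells (Homo sapiens) for inhibition, read by MTT assay, with a stated time of 48 h; on this read-out higher numbers stand for weaker inhibition and lower numbers for stronger inhibition:
- compound 1 `O=C(CCCCCCOc1no[n+]([O-])c1S(=O)(=O)c1ccccc1)NO`: 4090 nM
- compound 2 `CC(C)(COc1no[n+]([O-])c1S(=O)(=O)c1ccccc1)C(=O)NO`: 6360 nM

Compound 1 stands level with compound 2, as their two values lie within the usual scatter of each other. Compound 3 `O=C(NO)OCCOCCOc1no[n+]([O-])c1S(=O)(=O)c1ccccc1` has not yet been measured. It carries 2-((hydroxycarbamoyl)oxy)ethoxy in place of 4-(hydroxycarbamoyl)butyl on a saturated chain carbon, two bonds along the chain from an oxygen on an aromatic ring. Among the measured compounds shown here, no measured pair isolates this change, so the expectation rests on a loose comparison: with a different chain on the shared core, compound 2 gives 6360 nM and compound 1 gives 4090 nM in this assay. Only a small shift toward weaker inhibition, not beyond the scatter, is expected (a 1.5-fold higher number from compound 1 to compound 3 (0.17 log units; within the scatter)). The estimated value for compound 3 is 6000 nM, with an expected range of 2500 nM to 15000 nM.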

Compound 3, half-maximal inhibitory concentration: 5140 nM
The estimate for compound 3 lay 1.2-fold (0.07 log units) above the measured number; the measured number falls inside the stated range.
By their numbers in this assay, from the lowest: compounds 1, 3 and 2 (each within the scatter of the next).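

In this assay the entry of 2-((hydroxycarbamoyl)oxy)ethoxy in place of 4-(hydroxycarbamoyl)butyl on a saturated chain carbon, two bonds along the chain from an oxygen on an aromatic ring, gives a 1.3-fold higher number from compound 1 to compound 3 (0.10 log units; within the scatter) and leaves the two compounds level. This position therefore tolerates a chain of 3 carbon and 4 oxygen atoms in place of one of 5 carbon and 2 oxygen atoms, with 4 hydrogen-bond acceptors instead of 2, and no readable loss on this read-out. No accompanying measurement bears on why the two chains read alike.

The compounds shown leave open whether a carboxylic acid or a primary amine at the chain end would keep this level. How a longer chain would read on the shared core also remains unsettled.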